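The source may hold more compounds than are shown below. What is called first, only, known or untested is meant among the compounds shown, and "the series" means these compounds.

Three compounds share one core, in which a piperidinone bearing two fluorinated benzylidene arms carries a sulfonyl-linked benzene ring, and they differ in what sits on that ring and where the fluorine atoms sit on the arms. Compound 1 `N#Cc1ccc(S(=O)(=O)N2C/C(=C\c3ccccc3F)C(=O)/C(=C/c3ccccc3F)C2)cc1` carries a nitrile; in a functional assay on HepG2 cells (Homo sapiens) for cytotoxicity, read by MTT assay, with a stated time of 24 h (a lower number here means a stronger inhibitor, a higher number a weaker inhibitor), compound 1 gives 16500 nM. Compound 2 `O=C1/C(=C/c2cccc(F)c2)CN(S(=O)(=O)c2ccc(Br)cc2)C/C1=C\c1cccc(F)c1` carries a bromine, and in this assay compound 2 gives 7700 nM. Compound 3 `O=C1/C(=C/c2ccc(F)cc2)CN(S(=O)(=O)c2ccc(O[N+](=O)[O-])cc2)C/C1=C\c1ccc(F)cc1` carries a nitrooxy group, and in this assay compound 3 gives 5400 nM. The values of compound 3 and compound 2 lie within the scatter of each other, so no order between them can be read; compound 1 alone stands beyond the scatter, with a clearly higher number than compound 3.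

Compound 4 `O=C1/C(=C/c2ccc(F)cc2)CN(S(=O)(=O)c2ccc(F)cc2)C/C1=C\c1ccc(F)cc1` is obtained from compound 3 by one change: fluoro in place of nitrooxy on an aromatic carbon. Within the data shown here, no measured pair shows what such a swap does here, and the three measured compounds differ in more than one place at once, so no trend can be borrowed. The step expected from compound 3 to compound 4 in this assay is a 1.4-fold higher number from compound 3 to compound 4 (0.14 log units; within the scatter), a modest rise that may well stay inside the scatter. Compound 4 is therefore expected to give about 7500 nM in this assay, with a plausible range from 3000 nM to 19000 nM.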

Compound 4, half-maximal inhibitory concentration: 8100 nM
Beside the measured number, compound 4's estimate is 1.1-fold (0.03 log units) below it, and the stated range covers the measured number.
By their numbers in this assay, from the lowest: compounds 3, 2 and 4 (each within the scatter of the next); then compound 1.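

Among these compounds, compound 4 gives the first comparison here in which only one place differs: the fluorinated arms and the rest of the shared core stay the same, while 4-(nitrooxy)phenyl becomes 4-fluorophenyl. In this assay this swap gives a 1.5-fold higher number from compound 3 to compound 4 (0.18 log units; within the scatter) and so does not separate the two compounds, even though a group of four heavy atoms with a double bond gives way to a single fluorine atom at this place, para to a large group. The nitrooxy group is therefore not shown to be needed for the value of compound 3, and the data offer no explanation for this outcome.

Still open, going by these compounds, is how this position responds to groups of other kinds, such as an amine, a carboxylic acid or a longer chain, and whether any of them would move the number beyond the scatter. Also open, on these data alone, is whether the same swap would read alike with the arms of compound 1 or compound 2, and those two compounds differ from compound 4 in more than one place.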